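The compounds below may be only part of what the source reports. "The series", "measured", "known", "first", "only" and "open" are said of these compounds alone.

Working notes on the series. Compound 1 `COc1cccc(CNCCCNc2ccnc3cc(Oc4ccc(Cl)cc4)ccc23)c1O` and compound 2 `COc1ccccc1Oc1ccc2c(NCCCNCc3cccc(OC)c3O)ccnc2c1` share the same core and differ only in the aryl group on an oxygen on an aromatic ring. In a physicochemical assay for acid dissociation, compound 1 gives 9.28. In this assay, going by the values given here, compound 2 gives 9.28, and the step of no change at the digits printed from compound 1 to compound 2 (within the scatter) is flat, so compound 2 stands level with compound 1 on the one read-out available, with no other measured compound to compare against.

Compound 3 `COc1cccc(CNCCCNc2ccnc3cc(CCc4ccccc4)ccc23)c1O` is the next entry. Relative to compound 2 the change is phenethyl in place of 2-methoxyphenoxy on an aromatic carbon. Among the compounds with values here, the only measured step that bears on this position is no change at the digits printed from compound 1 to compound 2 (within the scatter), where swapping one aryl group for another on the same oxygen left the acid dissociation constant unmoved. Compound 3 goes further, replacing the whole 2-methoxyphenoxy by phenethyl, but the rest of compound 2 is carried over unchanged, and nothing in the measured pair suggests this position governs the read-out. The step that this estimate means, no change at the digits printed from compound 2 to compound 3 (within the scatter), is expected to stay within the scatter. For compound 3 the expected value is 9.28, with a range from 8.95 to 9.6.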

Compound 3, acid dissociation constant: 9.47
Beside the measured number, compound 3's estimate is 0.19 log units below it; low and high end bracket the measured number.
By their numbers in this assay, from the lowest: compounds 1, 2 and 3 (each within the scatter of the next).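

In this assay, the earlier step only exchanged one aryl group for another on the same oxygen, whereas phenethyl removes that oxygen from the position altogether, and the result is a number 0.19 log units higher from compound 2 to compound 3 (within the scatter), alongside a number 0.19 log units higher from compound 1 to compound 3 (within the scatter). The read-out at this aromatic carbon therefore stays within the scatter not only across two aryl groups on oxygen but also when 2-methoxyphenoxy, with 2 hydrogen-bond acceptors, gives way to phenethyl, with 0 hydrogen-bond acceptors and carbon alone among its heavy atoms. Nothing measured here explains this flat behaviour.

Whether the read-out would also stay within the scatter with an amine or a carboxylic acid on this aromatic carbon remains open, as all three compounds shown carry an uncharged group with one six-membered aromatic ring of carbon only there. Also open, on these data alone, is whether a change elsewhere, such as a longer chain in the part of the structure that all three compounds share, would move the read-out beyond the scatter.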